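A few compounds are considered here, and "the series" means these few. Any claim that something is new, unique, unknown or untested is made for them only; others in the source may bear on it.

Compound 1, `CCOc1cc(=O)n(CCCO)c2c1CC(C/C=C(\C)CCC=C(C)C)C(C)(C)C2`, gives 67.8% in a functional assay on PANC-1 cells (Homo sapiens) for inhibition, read by MTT assay, with a stated time of 24 h, tested at 10 uM; a lower number here means less inhibition, a higher number more inhibition at the concentration tested (going by the name of the read-out).
Compound 2, `CC(C)=CCC/C(C)=C/COc1cc(=O)n(CCCO)c2c1CC(C/C=C(\C)CCC=C(C)C)C(C)(C)C2`, gives 15.8% in this assay.
Compound 3, `CC(C)=CCC/C(C)=C/CC1Cc2c(OC(=O)Nc3ccc(F)cc3)cc(=O)n(CCCO)c2CC1(C)C`, gives 43.9% in this assay.

Among these three, compound 3 stands second highest: compound 1 lies above it and compound 2 below it, both beyond the scatter. The steps recorded so far all alter what sits on the oxygen of the shared core. Replacing the ethyl there by a (4-fluorophenyl)carbamoyl group gives a number 23.9 percentage points lower from compound 1 to compound 3 (beyond the scatter), while the same carbamoyl in place of the 3,7-dimethylocta-2,6-dien-1-yl group gives a number 28.1 percentage points higher from compound 2 to compound 3 (beyond the scatter); the largest movement, a number 52 percentage points lower from compound 1 to compound 2 (beyond the scatter), comes from swapping a methyl for a 2,6-dimethylhepta-1,5-dien-1-yl group on the saturated chain carbon bound to that oxygen.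

Compound 4, `CC(C)=CCC/C(C)=C/CC1Cc2c(OC(=O)Nc3ccc(F)c(Cl)c3)cc(=O)n(CCCO)c2CC1(C)C`, keeps the carbamoyl of compound 3 and differs only by chloro in place of hydrogen on an aromatic carbon. For the measured compounds named here, no measured step touches this aromatic ring at all, so none bears directly on the change; the carbamoyl group itself is present only in compound 3. With nothing to suggest a shift in either direction, the step of a number 0.1 percentage points higher from compound 3 to compound 4 (within the scatter) is expected to stay within the scatter. Compound 4 is therefore estimated at 44% in this assay, within a range from 25% to 63%.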

Compound 4, a percentage reported as inhibition, at one concentration (the size of the read-out at that concentration, not a potency): 25%
Estimate against measurement, compound 4: 19 percentage points above; the measured number falls inside the stated range.
By their numbers in this assay, from the lowest: compounds 2 and 4 (each within the scatter of the next); then compound 3; then compound 1.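

Chloro in place of hydrogen on an aromatic carbon, ortho to a fluoro group and meta to a large group, is the first change on this aromatic ring, and it gives a number 18.9 percentage points lower from compound 3 to compound 4 (beyond the scatter) in this assay, so this position of the (4-fluorophenyl)carbamoyl group does respond to substitution. With the (3-chloro-4-fluorophenyl)carbamoyl group on the oxygen, the comparison with the 3,7-dimethylocta-2,6-dien-1-yl group reads a number 9.2 percentage points higher from compound 2 to compound 4 (within the scatter), so the clear separation that the unchlorinated carbamoyl showed from that group is lost, while the comparison with ethyl reads a number 42.8 percentage points lower from compound 1 to compound 4 (beyond the scatter). What lies behind the effect of the chloro cannot be said from the data given here.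

On these data alone, whether this step belongs to chloro itself or would also follow from another group at this carbon, such as methyl, methoxy or a second fluoro, stays open, as does whether chloro would give the same step without the neighbouring fluoro group. The compounds shown also leave open how an amine or a carboxylic acid on this aromatic ring would read in this assay.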